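A few compounds are considered here, and "the series" means these few. Any claim that something is new, unique, unknown or untested is made for them only; others in the source may bear on it.

Measured compounds and their numbers:

Compound 1, `Cc1ccc(-c2cc(N3CCC(CNS(N)(=O)=O)CC3)ncn2)cc1`, gives 71000 nM.
Compound 2, `Cc1ccc(-c2cc(N3CCC(CCNS(N)(=O)=O)CC3)ncn2)cc1`, gives 57600 nM.
Compound 3, `CCCCc1ccc(-c2cc(N3CCC(CCNS(N)(=O)=O)CC3)ncn2)cc1`, gives 15100 nM.

In a functional assay on M21 cells (Homo sapiens) for antiproliferative activity, read by sulforhodamine B assay, with a stated time of 48 h (a lower number here means a stronger inhibitor of growth, a higher number a weaker inhibitor of growth), compound 2 sits second highest of the three numbers, close to compound 1 and well apart from compound 3. Compound 4, `NS(=O)(=O)NCCC1CCN(c2cc(-c3ccccc3F)ncn2)CC1`, differs from compound 2 in one place: 2-fluorophenyl in place of 4-methylphenyl on an aromatic carbon. Two measured steps give context. The step of a 1.2-fold lower number from compound 1 to compound 2 (0.09 log units; within the scatter) concerns the chain and says little about the aryl end. The step of a 3.8-fold lower number from compound 2 to compound 3 (0.58 log units; beyond the scatter) shows that enlarging the group on that ring lowers the number modestly; compound 4 instead removes the methyl and places a fluorine elsewhere on the ring, a change not sampled among the measured compounds. Within the data shown here, since the only ring step points to larger groups helping, a step of modest size toward a higher number is expected for a 1.5-fold higher number from compound 2 to compound 4 (0.17 log units; within the scatter), though a result within the scatter would not surprise. Compound 4 is estimated at 85000 nM, within 30000 nM to 250000 nM.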

Compound 4, concentration for 50% growth inhibition: 81800 nM
Estimate against measurement, compound 4: 1.0-fold (0.02 log units) above, within the range that was stated.
By their numbers in this assay, from the lowest: compound 3; then compounds 2, 1 and 4 (each within the scatter of the next).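

In this assay, 2-fluorophenyl in place of 4-methylphenyl gives a 1.4-fold higher number from compound 2 to compound 4 (0.15 log units; within the scatter), so this exchange of one aryl group for another leaves the number within the scatter. The two groups have the same count of heavy atoms, and this is the first change shown that alters the aryl group without enlarging it; the only step beyond the scatter on this group remains a 3.8-fold lower number from compound 2 to compound 3 (0.58 log units; beyond the scatter). No measurement shown here accounts for the result of compound 4.

Compound 4 loses the methyl and gains the fluorine in a single change, so the compounds shown cannot separate the two parts of that exchange; unsubstituted phenyl and 4-fluorophenyl would each isolate one part. From the compounds shown here alone, how an amine or a carboxylic acid on this aryl ring would read also remains open.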